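A few compounds are considered here, and "the series" means these few. Any claim that something is new, unique, unknown or untested is made for them only; others in the source may bear on it.

Working notes on the series. In an ADME assay on liver (Rattus norvegicus) for activation, read by HPLC (on this read-out lower numbers stand for a shorter-lived compound and higher numbers for a longer-lived compound), compound 1 `CCOC(=O)NCCCC(C)Nc1cc(OC)cc2cccnc12` gives 15.1 h, compound 2 `CCCCCCOC(=O)NCCCC(C)Nc1cc(OC)cc2cccnc12` gives 10.4 h and compound 3 `COc1cc(NC(C)CCCNC(=O)Oc2ccc(Cl)cc2)c2ncccc2c1` gives 11.8 h. Compound 3 therefore lies within the scatter of both other compounds, and no order can be read among the three.

Compound 4 `COc1cc(NC(C)CCCNC(=O)OCC(F)(F)F)c2ncccc2c1` differs from compound 3 by one change: 2,2,2-trifluoroethyl in place of 4-chlorophenyl on an oxygen next to a carbonyl group. In words, this is 2,2,2-trifluoroethyl in place of 4-chlorophenyl on an oxygen next to a carbonyl group.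

Two measured steps exchange the group at this same place: a 1.3-fold lower number from compound 1 to compound 3 (0.11 log units; within the scatter) and a 1.1-fold higher number from compound 2 to compound 3 (0.05 log units; within the scatter). The remaining step, a 1.5-fold lower number from compound 1 to compound 2 (0.16 log units; within the scatter), is equally small. Ethyl, hexyl and 4-chlorophenyl have thus been measured here without a step beyond the scatter, although 2,2,2-trifluoroethyl itself has not been measured.

No step beyond the scatter is expected in this assay. The estimate amounts to an expected 1.0-fold higher number from compound 3 to compound 4 (0.01 log units; within the scatter). For compound 4 the estimated half-life is 12 h, with an expected range of 6.5 h to 21 h.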

Compound 4, half-life in the liver assay: 13.7 h
Compound 4: middle estimate off by 1.1-fold (0.06 log units), on the low side; the measured number falls inside the stated range.
By their numbers in the liver assay, from the lowest: compounds 2, 3, 4 and 1 (each within the scatter of the next).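

In the liver assay the place on an oxygen next to a carbonyl group now also holds 2,2,2-trifluoroethyl with no step beyond the scatter, with a 1.2-fold higher number from compound 3 to compound 4 (0.06 log units; within the scatter) and a 1.3-fold higher number from compound 2 to compound 4 (0.12 log units; within the scatter) and a 1.1-fold lower number from compound 1 to compound 4 (0.04 log units; within the scatter) all read together. The four groups now compared here include one with a six-membered aromatic ring and others with no ring, and the half-life does not separate them. The half-life also did not follow lipophilicity across this pair, although a physicochemical assay for lipophilicity, read by HPLC, in phosphate buffer, measured as octanol-water partition, with a stated time of 30 min, at pH 7.4 (a higher number here means a more lipophilic compound, a lower number a more polar compound), separates compound 3 and compound 4 clearly: the measured distribution coefficient of compound 3, 4.44, and of compound 4, 3.41, a number 1.03 log units lower (beyond the scatter) In the physicochemical assay compound 3 gives 4.44 and compound 4 gives 3.41.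

The compounds shown do not tell what sets the half-life in this series, since no change at this place has yet moved it beyond the scatter. Open, going by these compounds, is whether an amine or a carboxylic acid in the group on this oxygen, or a change to the shared core, would do so.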